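Swapping Chlorophenyl Isomers in a Cytotoxicity Series

This account rests on a few compounds, and the source may have more. Where it says the series, first, only, none or still open, it means among the compounds named here.

Measured so far:
Compound 1 `Oc1cccc(-c2cc(-c3ccncc3)nc(-c3ccccc3Cl)c2)c1`: "not determined" (no result reported)
Compound 2 `Oc1cccc(-c2cc(-c3ccco3)nc(-c3ccccc3Cl)c2)c1`: 1860 nM
Compound 3 `Oc1cccc(-c2cc(-c3ccc(Cl)cc3)nc(-c3ccsc3)c2)c1`: 11200 nM

All three share a core with a six-membered aromatic ring with 1 nitrogen carrying a 3-hydroxyphenyl group. In an ADME assay on HEK293 cells (Homo sapiens) for cytotoxicity, read by CCK-8 assay and cell counting, with a stated time of 2 days (on this read-out higher numbers stand for weaker inhibition and lower numbers for stronger inhibition), compound 3 gives 11200 nM, the highest of the two numbers reported, while compound 2 gives 1860 nM, a gap beyond the usual scatter; compound 1 has no result. Compound 4 `Oc1cccc(-c2cc(-c3ccsc3)nc(-c3ccccc3Cl)c2)c1` holds the same atoms as compound 3, joined differently: 2-chlorophenyl in place of 4-chlorophenyl on an aromatic carbon. Going by the values given here, no such step has been measured here. Compound 4 is expected to show a moderate drop from compound 3 in this assay, a step of a 3.2-fold lower number from compound 3 to compound 4 (0.51 log units; beyond the scatter), because compound 2, which also carries 2-chlorophenyl, gives 1860 nM. Compound 4 is estimated at 3500 nM, between 1200 nM and 11000 nM.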

Compound 4, half-maximal inhibitory concentration: 2720 nM
The estimate for compound 4 lay 1.3-fold (0.11 log units) above the measured number, and the stated range covers the measured number.
By their numbers in this assay, from the lowest: compounds 2 and 4 (each within the scatter of the next); then compound 3.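

In this assay, going by these compounds alone, the position next to the ring nitrogen responds to where the chlorine sits on its phenyl ring: 2-chlorophenyl in place of 4-chlorophenyl gives a 4.1-fold lower number from compound 3 to compound 4 (0.61 log units; beyond the scatter) with only that isomer swap. With 2-chlorophenyl kept, thiophen-3-yl in place of furan-2-yl gives a 1.5-fold higher number from compound 2 to compound 4 (0.17 log units; within the scatter) and so leaves the read-out unchanged within the usual scatter. Nothing measured here explains the isomer effect.

Still open, from the compounds shown here alone, is how 3-chlorophenyl would compare with these two isomers. Also open, going by these compounds, is whether an amine in place of the chlorine would keep the lower number.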